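This account rests on a few compounds, and the source may have more. Where it says the series, first, only, none or still open, it means among the compounds named here.

Compound 1 `CCC(C)O[C@@H]1C[C@@H]2[C@H]([C@]1(N)C(=O)O)[C@@]2(F)C(=O)O` gives 6.68 nM in an assay on CHO cells for binding affinity to metabotropic glutamate receptor 2 (Rattus norvegicus); on this read-out lower numbers stand for stronger inhibition and higher numbers for weaker inhibition.
Compound 2 `N[C@]1(C(=O)O)[C@H]2[C@@H](C[C@H]1OCc1ccccc1)[C@]2(F)C(=O)O` gives 7.14 nM in this assay.
Compound 3 `N[C@]1(C(=O)O)[C@H]2[C@@H](C[C@H]1OCc1ccccc1-c1ccccc1)[C@]2(F)C(=O)O` gives 4.07 nM in this assay.

Compound 2 shows the highest of the three numbers, yet both neighbouring steps, a 1.1-fold higher number from compound 1 to compound 2 (0.03 log units; within the scatter) and a 1.8-fold lower number from compound 2 to compound 3 (0.24 log units; within the scatter), lie within the scatter, so no order among the three can be claimed. Compound 4 `N[C@]1(C(=O)O)[C@H]2[C@@H](C[C@H]1OCc1cccc(-c3ccccc3)c1)[C@]2(F)C(=O)O` differs from compound 2 by phenyl in place of hydrogen on an aromatic carbon. Among the measured compounds shown here, the one measured step that bears on this change is the move from compound 2 to compound 3, also a phenyl in place of hydrogen on an aromatic carbon, and it stayed within the scatter. The step to compound 4 is therefore expected to be small and at most slightly downward: a 1.3-fold lower number from compound 2 to compound 4 (0.11 log units; within the scatter). Compound 4 is estimated at 5.5 nM, with a range from 2.5 nM to 12 nM.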

Compound 4, inhibition constant: 9.34 nM
Beside the measured number, compound 4's estimate is 1.7-fold (0.23 log units) below it, and the stated range covers the measured number.
By their numbers in this assay, from the lowest: compounds 3, 1, 2 and 4 (each within the scatter of the next, the first and the last beyond it).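

Phenyl in place of hydrogen on an aromatic carbon, here meta to a large group, gives a 1.3-fold higher number from compound 2 to compound 4 (0.12 log units; within the scatter) in this assay, so at this second place too the added ring brings no readable change. Among the compounds shown here, compound 3 gives 4.07 nM and compound 4 gives 9.34 nM, and these two, which carry the phenyl at different places, are the only pair here beyond the scatter. Nothing available explains that gap. Going by these compounds, whether an amine or a carboxylic acid on this aromatic carbon would stay within the same range remains open.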